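One More Chain Carbon on Compound 2

A few compounds are considered here, and "the series" means these few. Any claim that something is new, unique, unknown or untested is made for them only; others in the source may bear on it.

Compound 1 (`CCCCCOc1c(-c2cc(OC)c(OC)c(OC)c2)oc2ccccc2c1=O`) and compound 2 (`CCCCCCOc1c(-c2cc(OC)c(OC)c(OC)c2)oc2ccccc2c1=O`) share one core and differ in one place, on the saturated chain. In a functional assay on PC-3 cells (Homo sapiens) for antiproliferative activity, read by WST assay, with a stated time of 3 days (a lower number here means a stronger inhibitor, a higher number a weaker inhibitor), compound 1 gives 22200 nM and compound 2 gives 29200 nM. Going by the values given here, compound 2 therefore stands within the usual scatter of compound 1, the only other compound measured, and the pair cannot be ranked.

Compound 3 (`CCCCCCCOc1c(-c2cc(OC)c(OC)c(OC)c2)oc2ccccc2c1=O`) carries the next change along that chain: methyl in place of hydrogen on a saturated chain carbon, six bonds along the chain from an oxygen on an aromatic ring. This is a methyl in place of hydrogen on a saturated chain carbon, six bonds along the chain from an oxygen on an aromatic ring. Among the compounds with values here, the only measured step that bears on it is the same replacement five bonds along the chain, a 1.3-fold higher number from compound 1 to compound 2 (0.12 log units; within the scatter). That single step lies within the scatter and establishes no trend, so no step beyond the scatter is expected in this assay. The expected change is a 1.0-fold higher number from compound 2 to compound 3 (0.01 log units; within the scatter). Compound 3 is estimated at about 30000 nM, with an expected range from 15000 nM to 60000 nM.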

Compound 3, half-maximal inhibitory concentration: > 50000 nM
Compound 3 gave a limit, no number; the forecaster's own chance of this, stated with the estimate: 10%; at least 1.6-fold (0.22 log units) between middle value and limit.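

In this assay, going by these compounds, compound 3 gives a limit of the assay and no number, so its true value stays unknown: the limit of > 50000 nM in this assay, at which 1 of the 3 values shown sits. At the position six bonds along the chain from an oxygen on an aromatic ring, the single methyl in place of hydrogen gives an at least 1.7-fold higher number from compound 2 to compound 3 (0.23 log units; that floor lies within the scatter), so this change alone still cannot be separated from the scatter. Going by these compounds alone, the longer comparison does show something that the earlier pair could not: the longer chain gives an at least 2.2-fold higher number from compound 1 to compound 3 (0.35 log units; beyond the scatter), the only step here that lies beyond the scatter, and it points toward a weaker inhibitor.

On these data alone, how far the true value of compound 3 lies past its limit remains open, and so does whether a still longer chain would continue in the same direction. The compounds shown also leave open what a shorter chain such as propyl or butyl would give at this oxygen, or how a chain ending in an amine or a carboxylic acid would read in this assay.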